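This account rests on a few compounds, and the source may have more. Where it says the series, first, only, none or still open, it means among the compounds named here.

Measured values in an ADME assay on J774 cells (Mus musculus) for cytotoxicity, read by MTT assay, with a stated time of 48 h, tested at 100 ug/mL; on this read-out lower numbers stand for a stronger effect and higher numbers for a weaker effect at the one concentration tested:

- compound 1 `O=C(N/N=C/c1ccccc1Cl)c1cnccn1`: 66%
- compound 2 `O=C(N/N=C/c1ccc(Cl)cc1)c1cnccn1`: 64%
- compound 3 `O=C(N/N=C/c1cccc(F)c1)c1cnccn1`: 46%

Compound 1 carries the highest of the three numbers. Compound 2 lies nearest to it, and the gap between the two falls within the usual scatter of repeated measurements, so no order between compound 1 and compound 2 can be claimed. Compound 3 lies furthest from compound 1, and that gap is beyond the scatter. None of the three measured compounds differ from one another in a single place, so no single-step comparison within the measured set is available.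

Compound 4 `COc1ccccc1/C=N/NC(=O)c1cnccn1` is the next compound for this assay. Against compound 1 the change is methoxy in place of chloro on an aromatic carbon. Within the data shown here, there is no measured pair showing the effect of this particular exchange, and the numbers for compound 1 and compound 2, which both carry chloro and give values within the scatter of each other, offer no guidance on its direction. The step of a number 6 percentage points lower from compound 1 to compound 4 (within the scatter) is therefore expected to be small, with no clear direction beyond the scatter, and a wide range is kept. Compound 4 is estimated to give about 60% in this assay, within 40% to 80%.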

Compound 4, a percentage reported as activity, at one concentration (the size of the read-out at that concentration, not a potency): 100%
Compound 4: the middle estimate sits 40 percentage points below what was measured; the whole stated range lies below it.
By their numbers in this assay, from the lowest: compound 3; then compounds 2 and 1 (each within the scatter of the next); then compound 4.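

Working notes on the series: in this assay, the exchange of chloro for methoxy on an aromatic carbon, ortho to a large group, gives a number 34 percentage points higher from compound 1 to compound 4 (beyond the scatter) and so moves the read-out towards a weaker effect at the one concentration tested. Among these compounds, this is the first comparison in which only one place differs, and it shows that the group at this position can change the read-out by more than the usual scatter, so the position cannot be treated as indifferent to substitution. No measurement shown bears on why this exchange has so large an effect, and the step therefore stands as an observation only.

The compounds shown leave open whether the step follows from the arrival of methoxy or from the departure of chloro, a question that an amine, a hydroxyl group or a longer ether chain such as ethoxy at the same position would help to separate. They also leave open whether methoxy in place of chloro on compound 2 would give a step of similar size and direction, so the result is so far tied to this single pair.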